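The source may hold more compounds than are shown below. What is called first, only, known or untested is meant among the compounds shown, and "the series" means these compounds.

Measured in an ADME assay on C8166 cells (Homo sapiens) for cytotoxicity, read by MTT assay; a higher number here means that more compound is tolerated, a lower number that less compound is tolerated
- compound 1 `O=C(O)c1cn(Cc2ccccc2)c2ccc(Cc3cccc(Cl)c3F)c(O)c2c1=O` 20300 nM
- compound 2 `O=C(O)c1cn(Cc2ccccc2F)c2ccc(Cc3cccc(Cl)c3F)c(O)c2c1=O` 44900 nM

Compound 2 stands highest of these two numbers, with compound 1 nearest. Compound 3 `O=C(O)c1cn(Cc2ccc(F)cc2)c2ccc(Cc3cccc(Cl)c3F)c(O)c2c1=O` follows, with this change: 4-fluorophenyl in place of 2-fluorophenyl on a saturated chain carbon bound to an aromatic nitrogen. Within the data shown here, the only measured step bearing on it is modest, a 2.2-fold higher number from compound 1 to compound 2 (0.34 log units; beyond the scatter) (fluoro in place of hydrogen on an aromatic carbon), and no measured pair compares the two fluorophenyl groups. In this assay a small downward move, not beyond the scatter, is expected: a 1.3-fold lower number from compound 2 to compound 3 (0.11 log units; within the scatter) (estimated). Estimated for compound 3: 35000 nM (range 18000 nM to 70000 nM).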

Compound 3, half-maximal cytotoxic concentration: 65800 nM
Beside the measured number, compound 3's estimate is 1.9-fold (0.27 log units) below it, and the stated range covers the measured number.
By their numbers in this assay, from the lowest: compound 1; then compounds 2 and 3 (each within the scatter of the next).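

In this assay, 2-fluorobenzyl and 4-fluorobenzyl on the aromatic nitrogen are not separated (a 1.5-fold higher number from compound 2 to compound 3 (0.17 log units; within the scatter)), so the two fluorine placements read as equivalent here. The step from the unsubstituted benzyl group now holds for the 4-fluorobenzyl group as well (a 3.2-fold higher number from compound 1 to compound 3 (0.51 log units; beyond the scatter)), so compound 2 and compound 3 both stand apart from compound 1. Nothing shown gives a reason for either step. Still open, from the compounds shown here alone, is whether this step is particular to fluoro or would carry over to a chlorophenyl or methoxyphenyl group at this position.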